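Benzoyl in Place of the Nine-Atom Group on Two Cores

A few compounds are considered here, and "the series" means these few. Any claim that something is new, unique, unknown or untested is made for them only; others in the source may bear on it.

Values in a functional assay on the whole organism (strain albino) for inhibition, with Rattus norvegicus as the target, read by paw edema, with a stated time of 3 h, at a dose of 0.28 mmol/kg by the oral route; on this read-out higher numbers stand for more inhibition at the one dose given (going by the name of the read-out) and lower numbers for less inhibition:
compound 1 `COc1ccc(-c2nnc(SC/C(=N/O)c3ccccc3)n2-c2ccccc2)cc1` gives 63%
compound 2 `C=CCn1c(SC/C(=N/O)c2ccccc2)nnc1-c1cc(OC)c(OC)c(OC)c1` gives 70%
compound 3 `COc1ccc(-c2nnc(SCC(=O)c3ccccc3)n2-c2ccccc2)cc1` gives 58%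

Compound 1 and compound 2 differ in more than one place; the difference between the two cores is not broken down here. From compound 1 to compound 3 the change is a group of 8 heavy atoms (7 carbon, 1 oxygen; one six-membered aromatic ring of carbon only) in place of a group of 9 heavy atoms (7 carbon, 1 nitrogen, 1 oxygen; one six-membered aromatic ring of carbon only), on a saturated chain carbon bound to a sulfur, and it gave a number 5 percentage points lower from compound 1 to compound 3 (within the scatter). Compound 4 `C=CCn1c(SCC(=O)c2ccccc2)nnc1-c1cc(OC)c(OC)c(OC)c1` is not yet measured; it arises from compound 2 by a group of 8 heavy atoms (7 carbon, 1 oxygen; one six-membered aromatic ring of carbon only) in place of a group of 9 heavy atoms (7 carbon, 1 nitrogen, 1 oxygen; one six-membered aromatic ring of carbon only), on a saturated chain carbon bound to a sulfur, the same change at the same place. The step in this assay is expected to be a number 5 percentage points lower from compound 2 to compound 4 (within the scatter), beside the earlier one, because a number 5 percentage points lower from compound 1 to compound 3 (within the scatter) lay within the scatter and nothing in the three measured compounds points another way. Compound 4 is estimated at 65%, with a range of 53% to 76%.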

Compound 4, a percentage reported as inhibition, in the whole organism at one dose (the size of the read-out at that dose, not a potency): 66%
Compound 4: the middle estimate sits 1 percentage points below what was measured; the range from low to high includes it.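

In this assay, the exchange for benzoyl on the second core gives a number 4 percentage points lower from compound 2 to compound 4 (within the scatter). Set beside the step on the first core, the exchange carries over with no difference that can be told apart: the same change on two cores in this assay, a number 5 percentage points lower (within the scatter) from compound 1 to compound 3 and a number 4 percentage points lower (within the scatter) from compound 2 to compound 4, 1 percentage points apart, within the scatter of two such steps. Both steps lie within the scatter, so the two cores agree only in showing no clear effect of this exchange at one dose and one time, and they do not show how it would read on a third core.

The compounds shown leave open how an amine, a carboxylic acid or a longer chain in place of benzoyl would read in this assay. They also leave open whether the two cores would still agree at other doses or times.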